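Amide change from compound 2 to compound 3

A few compounds are considered here, and "the series" means these few. Any claim that something is new, unique, unknown or untested is made for them only; others in the source may bear on it.

Measured in a physicochemical assay for solubility, read by spectrophotometry, measured as kinetic solubility, at pH 8, tested at 500 uM; a lower number here means a less soluble compound, a higher number a more soluble compound:
- compound 1 `Cn1cc(CNC(=O)c2ccncc2Nc2cc(-c3ccc4ccn(C)c4c3)c3nccnc3c2)cn1` gives 127 ug/mL
- compound 2 `CN1CCC(N(C)C(=O)c2ccncc2Nc2cc(-c3ccc4ccn(C)c4c3)c3nccnc3c2)C1` gives 245 ug/mL

For the measured compounds named here, compound 2 cannot be separated from compound 1 on these numbers, as the only measured step lies within the scatter (a 1.9-fold higher number from compound 1 to compound 2 (0.29 log units; within the scatter)). The next structure is compound 3 `CC(=O)N1CCC(NC(=O)c2ccncc2Nc2cc(-c3ccc4ccn(C)c4c3)c3nccnc3c2)C1`, which carries (1-acetylpyrrolidin-3-yl)amino in place of methyl(1-methylpyrrolidin-3-yl)amino on a carbonyl carbon, and the counted difference is (1-acetylpyrrolidin-3-yl)amino in place of methyl(1-methylpyrrolidin-3-yl)amino on a carbonyl carbon in full.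

Going by the values given here, no measured step makes this exact change. The step from compound 1 to compound 2 bears on it only indirectly, as it exchanges a different group at the same place, and its size is the one given above. On that single step, no change beyond the scatter is expected in this assay, with at most a weak expected lean towards lower numbers. The expected step is small (a 1.5-fold lower number from compound 2 to compound 3 (0.19 log units; within the scatter)). Compound 3 is estimated at 160 ug/mL (expected range 70 ug/mL to 280 ug/mL).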

Compound 3, solubility: 253 ug/mL
Estimate against measurement, compound 3: 1.6-fold (0.20 log units) below, within the range that was stated.
By their numbers in this assay, from the lowest: compounds 1, 2 and 3 (each within the scatter of the next).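

Notes on the amide position, read in this assay: exchanging methyl(1-methylpyrrolidin-3-yl)amino for (1-acetylpyrrolidin-3-yl)amino on the carbonyl carbon gives a 1.0-fold higher number from compound 2 to compound 3 (0.01 log units; within the scatter), so a neutral acetyl group on the ring nitrogen, together with the amide hydrogen that now appears, leaves no readable difference at this position. The second new comparison, with 1-acetylpyrrolidin-3-yl in place of (1-methyl-1H-pyrazol-4-yl)methyl on the amide-type nitrogen, gives a 2.0-fold higher number from compound 1 to compound 3 (0.30 log units; within the scatter), which also stays within the scatter, so the three amide groups shown cannot be told apart in this read-out even though they differ in ring type and in the counted hydrogen-bond donors. No supporting measurement is available to explain why these groups read alike.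

As far as these compounds go, the change from compound 2 to compound 3 alters the amide nitrogen substituent and the ring nitrogen substituent together, so the share of each part remains open. Also open, from the compounds shown here alone, is whether a group of another kind at this place, such as a carboxylic acid or a primary amine on the pyrrolidine ring, would produce a step beyond the scatter.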